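Compound 4: Exchanging the Linker to the Chlorophenyl Group

The compounds below may be only part of what the source reports. "The series", "measured", "known", "first", "only" and "open" are said of these compounds alone.

Measured so far:
compound 1, `Cc1cc(-c2ccc(Cl)cc2)c(S(C)(=O)=O)cc1C(=O)N=C(N)N`, 45 nM
compound 2, `Cc1cc(SC(C)C)c(S(C)(=O)=O)cc1C(=O)N=C(N)N`, 12 nM
compound 3, `Cc1cc(Sc2ccc(Cl)cc2)c(S(C)(=O)=O)cc1C(=O)N=C(N)N`, 19 nM

In a functional assay for inhibition of sodium/hydrogen exchanger (Oryctolagus cuniculus) (on this read-out higher numbers stand for weaker inhibition and lower numbers for stronger inhibition), compound 3 gives 19 nM, the second highest of the three numbers. Its nearest neighbour is compound 2, a step of a 1.6-fold higher number from compound 2 to compound 3 (0.20 log units; within the scatter), which is within the scatter, so the two cannot be ordered. Its furthest neighbour is compound 1, and the step of a 2.4-fold lower number from compound 1 to compound 3 (0.37 log units; beyond the scatter) is modest but beyond the scatter.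

Compound 4, `Cc1cc(Oc2ccc(Cl)cc2)c(S(C)(=O)=O)cc1C(=O)N=C(N)N`, has not yet been measured. It differs from compound 3 in one place: 4-chlorophenoxy in place of (4-chlorophenyl)sulfanyl on an aromatic carbon. Among the compounds with values here, two measured steps bear on this change. The step of a 2.4-fold lower number from compound 1 to compound 3 (0.37 log units; beyond the scatter) shows that attaching the 4-chlorophenyl group through a sulfanyl linker rather than directly lowered the number modestly. The step of a 1.6-fold higher number from compound 2 to compound 3 (0.20 log units; within the scatter) shows that changing what sits on the sulfur moved the number only within the scatter. Within the data shown here, no measured step exchanges the linker itself, so the data give no direction for this change. Compound 4 is therefore expected to sit close to compound 3, with a step of about a 1.3-fold higher number from compound 3 to compound 4 (0.12 log units; within the scatter), which lies within the scatter. The estimate for compound 4 in this assay is 25 nM, in a range from 10 nM to 65 nM.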

Compound 4, half-maximal inhibitory concentration: 13 nM
Beside the measured number, compound 4's estimate is 1.9-fold (0.28 log units) above it; low and high end bracket the measured number.
By their numbers in this assay, from the lowest: compounds 2, 4 and 3 (each within the scatter of the next); then compound 1.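

In this assay, this position, ortho to a methylsulfonyl group, now has a direct exchange of the linker atom, and 4-chlorophenoxy and (4-chlorophenyl)sulfanyl cannot be told apart there (a 1.5-fold lower number from compound 3 to compound 4 (0.16 log units; within the scatter)). The isopropylsulfanyl group cannot be separated from 4-chlorophenoxy either (a 1.1-fold higher number from compound 2 to compound 4 (0.03 log units; within the scatter)), whereas the directly attached 4-chlorophenyl group stands apart (a 3.5-fold lower number from compound 1 to compound 4 (0.54 log units; beyond the scatter)), so two different linker atoms now carry the same chlorophenyl ring to a lower number than direct attachment does, and neither of those two compounds goes against this. Nothing measured here explains why the linked compounds differ from compound 1 or why oxygen and sulfur read alike.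

From the compounds shown here alone, it remains open whether an amine or a methylene linker would fall with the sulfur- and oxygen-linked compounds or with compound 1, which would show how general the effect of a linker is at this position. Going by these compounds, it is also open how the phenoxy group would read with its chlorine moved around the ring or replaced by a methoxy group or a nitrile.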